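The source may hold more compounds than are shown below. What is called first, only, known or untested is meant among the compounds shown, and "the series" means these compounds.

Measured so far:
- compound 1, `CCn1nc2oc(=O)cc(C)c2c1C`: 14.6 mg/kg
- compound 2, `Cc1cc(=O)oc2c1c(C)nn2CCO`: 100 mg/kg

In a functional assay on the whole organism with Mus musculus as the target, in the writhing test (on this read-out higher numbers stand for an effect only at larger amounts of compound and lower numbers for an effect already at smaller amounts), compound 1 gives 14.6 mg/kg, the lowest of the two numbers; in this assay compound 2 gives 100 mg/kg, a clearly higher number beyond the usual scatter. Compound 3, `Cc1cc(=O)oc2nn(CCO)c(C)c12`, is not yet measured. It differs from compound 1 by hydroxy in place of hydrogen on a saturated chain carbon, two bonds along the chain from an aromatic nitrogen. Going by the values given here, with no measured step of this kind to lean on, an upward step is expected: the estimated shift a 2.7-fold higher number from compound 1 to compound 3 (0.44 log units; beyond the scatter) goes toward a higher number, beyond the scatter but not necessarily reaching compound 2. Compound 3 is expected to give about 40 mg/kg, likely between 14 mg/kg and 110 mg/kg.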

Compound 3, dose for half-maximal effect: > 100 mg/kg
Compound 3 gave a limit, no number; the forecaster's own chance of this, stated with the estimate: 10%; middle value at least 2.5-fold (0.39 log units) away from the limit.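

Swapping ethyl for 2-hydroxyethyl is the first change at this position with a measured step: in this assay, it gives an at least 6.8-fold higher number from compound 1 to compound 3 (0.83 log units; beyond the scatter). A single hydroxy on this chain is therefore enough to shift the effect to clearly larger amounts of compound. Going by these compounds, the result for compound 3 is a limit, not a number, so the true size of the step remains unknown: the limit of > 100 mg/kg in this assay, at which 1 of the 3 values shown sits.

On these data alone, whether a methoxy or an amine at the same chain end, or a longer chain such as propyl, would give a similar shift remains open.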